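This account rests on a few compounds, and the source may have more. Where it says the series, first, only, none or still open, it means among the compounds named here.

Compound 1 `CCC(CC)O[C@@H]1C=C(C(=O)O)C[C@H](NCc2ccc(C(C)C)cc2)[C@H]1NC(C)=O` was tested in an ADME assay on cells (Fibroblast, Gallus gallus) for cytotoxicity, read by CCK-8 assay, with a stated time of 48 h; on this read-out lower numbers stand for higher toxicity in this test and higher numbers for lower toxicity in this test. In this assay compound 1 gives > 200000 nM, which is a limit of the assay rather than a number. Compound 2 `CCC(CC)O[C@@H]1C=C(C(=O)O)C[C@H](NCc2ccc(OC)cc2)[C@H]1NC(C)=O` carries a methoxy in place of the isopropyl on the aromatic carbon, and in this assay compound 2 gives > 200000 nM, again a limit. Compound 3 `CCC(CC)O[C@@H]1C=C(C(=O)O)C[C@H](NCc2ccc(Sc3cccs3)cc2)[C@H]1NC(C)=O` carries a (thiophen-2-yl)sulfanyl at that aromatic carbon, and in this assay compound 3 gives > 200000 nM, also a limit. Because every value sits at the limit of > 200000 nM in this assay, at which 3 of the 3 values shown sit, the step that the two limits leave unreadable from compound 1 to compound 2 cannot be sized, nor can a step that the two limits leave unreadable from compound 1 to compound 3 or a step that the two limits leave unreadable from compound 2 to compound 3. Compound 4 `CCC(CC)O[C@@H]1C=C(C(=O)O)C[C@H](NCc2ccc(-c3ccc(SC)cc3)cc2)[C@H]1NC(C)=O` differs from compound 1 by 4-(methylsulfanyl)phenyl in place of isopropyl on an aromatic carbon. The two measured replacements at the same aromatic carbon bear on this step, yet both gave only limits, so no direction or size can be read from them. Compound 4 is therefore expected to show no readable change either, with an expected step that the limit leaves unreadable from compound 1 to compound 4. The estimate for compound 4 in this assay is 300000 nM, within 150000 nM to 1000000 nM.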

Compound 4, half-maximal cytotoxic concentration: > 200000 nM
Compound 4: a limit, no number; the forecaster's own chance of this, stated with the estimate: 85%; the middle value is on the limit's open side.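

Compound 4 also gives only a limit in this assay, so no step between it and compound 1, compound 2 or compound 3 can be read: the limit of > 200000 nM in this assay, at which 4 of the 4 values shown sit.

The compounds shown leave open whether any of these replacements on the aromatic carbon changes toxicity in this assay and at what concentration any toxicity would appear.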